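Compound 4: a smaller side chain replaces the benzyl ester

The source may hold more compounds than are shown below. What is called first, only, known or untested is meant among the compounds shown, and "the series" means these compounds.

Compound 3 `O=C(CN(c1ncnc2c1ncn2C1CCCCO1)C1CC1)N[C@@H](CC(=O)OCc1ccccc1)C(=O)OCc1ccccc1` has the lowest number of the three measured compounds: in a functional assay on the whole organism (Tail, strain ICR) with Mus musculus as the target, in the tail flick test, with a stated time of 120 min, at a dose of 25 umol/kg by the oral route (a higher number here means a stronger effect of the compound at the dose given, a lower number a weaker effect), compound 3 gives 7.82%, beneath compound 1 `O=C(CN(c1ncnc2c1ncn2C1CCCCO1)C1CC1)N[C@@H](CCC(=O)OCc1ccccc1)C(=O)OCc1ccccc1` at 20.7% and compound 2 `O=C(CN(c1ncnc2c1ncn2C1CCCCO1)C1CC1)N[C@@H](CO)C(=O)OCc1ccccc1` at 29.2%. Compound 4 `N=C(N)NCCC[C@H](NC(=O)CN(c1ncnc2c1ncn2C1CCCCO1)C1CC1)C(=O)OCc1ccccc1` differs from compound 3 by a group of 6 heavy atoms (3 carbon, 3 nitrogen; no ring) in place of a group of 10 heavy atoms (8 carbon, 2 oxygen; one six-membered aromatic ring of carbon only), on a saturated chain carbon, two bonds along the chain from an amide-type nitrogen and a carbonyl carbon. Among the measured compounds shown here, two measured steps bear on this change: a number 21.4 percentage points lower from compound 2 to compound 3 (beyond the scatter) and a number 12.9 percentage points lower from compound 1 to compound 3 (beyond the scatter). Both place the benzyloxycarbonyl group of compound 3 at the weak end of the set. Taking that group away in compound 4 is therefore expected to raise the number somewhat, although the entering group has no measured counterpart here, so the step is estimated at a number 12.2 percentage points higher from compound 3 to compound 4 (beyond the scatter). Compound 4 is expected to give about 20% in this assay, within a likely range from 5% to 40%.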

Compound 4, a percentage reported as activity, at one dose (the size of the read-out at that dose, not a potency): 38.2%
For compound 4 the middle estimate is 18.2 percentage points below the measured one; measured number inside the range.
By their numbers in this assay, from the lowest: compound 3; then compounds 1, 2 and 4 (each within the scatter of the next, the first and the last beyond it).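

At this saturated chain carbon, the nitrogen-bearing group of compound 4 gives a number 30.4 percentage points higher from compound 3 to compound 4 (beyond the scatter) and a number 17.5 percentage points higher from compound 1 to compound 4 (beyond the scatter) in this assay, showing that a group with no ring can stand here without loss against either benzyl ester side chain. Against the hydroxy group the step is a number 9 percentage points higher from compound 2 to compound 4 (within the scatter), so these two side chains cannot be ranked. Nothing shown explains these steps. Going by these compounds, it remains open whether a simple amine or a carboxylic acid at the end of this chain would match compound 4, and whether a shorter or longer chain would change the number.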